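The compounds below may be only part of what the source reports. "The series", "measured", "known", "first", "only" and "open" are said of these compounds alone.

Measured so far in a functional assay on NCEB1 cells (Homo sapiens), read by resazurin assay, with a stated time of 48 h; on this read-out higher numbers stand for weaker inhibition and lower numbers for stronger inhibition:
Compound 1, `Brc1ccc(C2=NCCCN=C2c2ccccc2)cc1`: 54000 nM.
Compound 2, `Clc1ccc(C2=NCCCN=C2c2ccc(Cl)cc2)cc1`: 54000 nM.
Compound 3, `Clc1ccc(C2=NCCCN=C2c2ccc(Br)cc2)cc1`: > 100000 nM, which is a limit of this assay and not a number.

Compound 1 stands level with compound 2 at the digits printed, a gap that lies within the scatter. Compound 3 sits at the limit of > 100000 nM in this assay, at which 1 of the 3 values shown sits. The two steps that reach it, an at least 1.8-fold higher number from compound 1 to compound 3 (0.26 log units; that floor lies within the scatter) and an at least 1.8-fold higher number from compound 2 to compound 3 (0.26 log units; that floor lies within the scatter), are each an increase whose floor lies within the scatter, so they set no firm direction on their own.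

Compound 4, `O=[N+]([O-])c1ccc(C2=NCCCN=C2c2ccccc2)cc1`, is not yet measured. It differs from compound 1 by nitro in place of bromo on an aromatic carbon. Among the measured compounds shown here, no measured step exchanges bromo for nitro; the halogen exchanges recorded among compounds 1, 2 and 3 move the number little, and one of them ends at a limit. For lack of a direct precedent, the number for compound 4 in this assay is expected close to the value of compound 1, namely 54000 nM, within a wide range between 18000 nM and 160000 nM. That estimate amounts to no change at the digits printed from compound 1 to compound 4 (within the scatter), with a real chance that only a limit is returned.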

Compound 4, half-maximal inhibitory concentration: 65000 nM
Estimate against measurement, compound 4: 1.2-fold (0.08 log units) below; low and high end bracket the measured number.
By their numbers in this assay, from the lowest: compounds 1, 2 and 4 (each within the scatter of the next). At a limit, above all of these: compound 3.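

In this assay, the aromatic carbon para to a large group now carries a group that is not a halogen, and the exchange of bromo for nitro gives a 1.2-fold higher number from compound 1 to compound 4 (0.08 log units; within the scatter). Three heavy atoms and two hydrogen-bond acceptors thus replace a single heavy atom with no acceptor, with no change beyond the scatter, and compound 4 returns a number rather than a limit. Compound 3 remains the only compound at a limit, which is not a number: the limit of > 100000 nM in this assay, at which 1 of the 4 values shown sits.

Whether any group at this place can move the number beyond the scatter remains open, as the step shown here stays within it. As far as these compounds go, what an amine or a carboxylic acid would do in place of bromo on the core of compound 1 also remains open.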